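Methoxy in place of hydrogen on compound 2

This account rests on a few compounds, and the source may have more. Where it says the series, first, only, none or still open, it means among the compounds named here.

Going by the values given here, the series so far holds compound 1 (`S=C(N/N=C/c1cccs1)Nc1ccc(Cl)cc1`), compound 2 (`S=C(N/N=C/c1cccs1)Nc1ccccc1`) and compound 3 (`S=C(N/N=C/c1cccs1)Nc1cccnc1`), all tested in a functional assay on PC-3 cells (Homo sapiens) for inhibition, read by sulforhodamine B assay, with a stated time of 48 h; a higher number here means a weaker inhibitor of growth, a lower number a stronger inhibitor of growth. Compound 1 gives > 100000 nM, which is a limit and not a number. Compound 2 gives > 100000 nM, also a limit. Compound 3 gives > 100000 nM, again a limit. Compound 2 therefore has no numerical position in the series and shares its reading with the other two: the limit of > 100000 nM in this assay, at which 3 of the 3 values shown sit.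

The next structure is compound 4 (`COc1ccc(NC(=S)N/N=C/c2cccs2)cc1`), with methoxy in place of hydrogen on an aromatic carbon, para to a large group: methoxy in place of hydrogen on an aromatic carbon.

Among the compounds with values here, the only measured step between two close analogues is a step that the two limits leave unreadable from compound 1 to compound 2, which exchanges hydrogen and chloro on an aromatic carbon. Its size cannot be read, so it gives no size to carry over, and it sets no direction for the methoxy change.

The expectation rests on compound 2, whose limit is > 100000 nM. The expected change is a number no higher from compound 2 to compound 4 (the limit leaves the size open), with no direction that can be stated, and another limit reading is the likeliest outcome in this assay. For compound 4 the estimate is 100000 nM, with an expected range from 30000 nM to 300000 nM.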

Compound 4, concentration for 50% growth inhibition: > 100000 nM
Compound 4: no number, only a limit; the forecaster's own chance of this, stated with the estimate: 80%; the middle value lies on the limit itself.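

Compound 4, like compound 1 and compound 2, reads only as a limit and not a number in this assay, so the steps from compound 2 and compound 1 to compound 4 cannot be read. The compounds shown leave open whether any change on the shared core gives a measurable value at all: the limit of > 100000 nM in this assay, at which 4 of the 4 values shown sit.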